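A few compounds are considered here, and "the series" means these few. Any claim that something is new, unique, unknown or untested is made for them only; others in the source may bear on it.

Compound 1 `COc1cc2c(Oc3ccc(NC(=O)c4nn(-c5ccccc5)cc(C)c4=O)cc3)ccnc2cc1OCCCCCCC(=O)NO`: in a functional assay on A549 cells (Homo sapiens) for inhibition, read by MTT assay, with a stated time of 72 h (a higher number here means a weaker inhibitor, a lower number a stronger inhibitor), compound 1 gives 420 nM.
Compound 2 `COc1cc2c(Oc3ccc(NC(=O)c4nn(-c5ccccc5F)cc(C)c4=O)cc3F)ccnc2cc1OCCCCCC(=O)NO`: in this assay compound 2 gives 1320 nM.
Compound 3 `COc1cc2c(Oc3ccc(NC(=O)c4nn(-c5ccc(C)cc5C)cc(C)c4=O)cc3)ccnc2cc1OCCCCCCC(=O)NO`: in this assay compound 3 gives 1840 nM.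

Of the three measured compounds, compound 3 carries the highest number, which here means the weakest inhibition. Its gap to compound 2 lies within the scatter of repeated measurements, so the two cannot be ranked; its gap to compound 1 lies beyond it, shown by the step of a 4.4-fold higher number from compound 1 to compound 3 (0.64 log units; beyond the scatter), where a 2,4-dimethylphenyl took the place of a plain phenyl on an aromatic nitrogen.

Compound 4 `COc1cc2c(Oc3ccc(NC(=O)c4nn(-c5ccc(F)c(Cl)c5)cc(C)c4=O)cc3)ccnc2cc1OCCCCCCC(=O)NO` differs from compound 3 in that same place: 3-chloro-4-fluorophenyl in place of 2,4-dimethylphenyl on an aromatic nitrogen. Within the data shown here, the one measured step that speaks to this position is the one from compound 1 to compound 3, in which adding two methyl groups to the phenyl weakened inhibition modestly. Among the measured compounds shown here, compound 4 returns to a phenyl carrying two small substituents, but of a different kind, and no measured pair shows what chlorine and fluorine on this ring do. The expectation is therefore a number between those of compound 1 and compound 3, and compound 4 is expected to show a step of a 2.3-fold lower number from compound 3 to compound 4 (0.36 log units; beyond the scatter) in this assay. Compound 4 is thus estimated at 800 nM, within a range from 300 nM to 2200 nM.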

Compound 4, half-maximal inhibitory concentration: 380 nM
For compound 4 the middle estimate is 2.1-fold (0.32 log units) above the measured one; measured number inside the range.
By their numbers in this assay, from the lowest: compounds 4 and 1 (each within the scatter of the next); then compounds 2 and 3 (each within the scatter of the next).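

In this assay, putting 3-chloro-4-fluorophenyl in place of 2,4-dimethylphenyl gives a 4.8-fold lower number from compound 3 to compound 4 (0.69 log units; beyond the scatter), so the weakening seen with compound 3 does not extend to every phenyl ring carrying two substituents. The comparison with the plain phenyl gives a 1.1-fold lower number from compound 1 to compound 4 (0.04 log units; within the scatter), which lies within the scatter, so compound 4 and compound 1 cannot be ranked, and this position accepts at least one doubly substituted phenyl without a measurable change in this assay. The two groups exchanged between compound 3 and compound 4 both have the same count of heavy atoms, so that count does not separate them, and nothing available here explains the difference between them.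

This change alters both the kind of substituent and where it sits on the ring, so the compounds shown cannot tell which of the two matters. Also open, on these data alone, is what happens with a phenyl carrying chlorine alone or fluorine alone, a single methyl group, or a larger or charged group such as a methoxy group, an amine or a carboxylic acid.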